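Indol-3-yl ketone on the shared core: expectation for compound 3

A few compounds are considered here, and "the series" means these few. Any claim that something is new, unique, unknown or untested is made for them only; others in the source may bear on it.

The shared core carries an unsaturated ketone whose group on the carbonyl carbon is varied. Compound 1 `COc1ccc(-c2cc3ccccc3nc2/C=C/C(=O)c2ccccc2)cc1` bears a phenyl there and in a functional assay on MCF7 cells (Homo sapiens) for antiproliferative activity, read by XTT assay, with a stated time of 72 h (a lower number here means a stronger inhibitor, a higher number a weaker inhibitor), compound 1 gives 4040 nM. Compound 2 `COc1ccc(-c2cc3ccccc3nc2/C=C/C(=O)c2ccc[nH]2)cc1` carries a 1H-pyrrol-2-yl in the same place. For compound 2 this assay reports only a limit, > 10000 nM (the limit of > 10000 nM in this assay, at which 1 of the 2 values shown sits). The step of an at least 2.4-fold higher number from compound 1 to compound 2 (0.39 log units; beyond the scatter) is the only one measured and runs toward weaker inhibition. Compound 3 `COc1ccc(-c2cc3ccccc3nc2/C=C/C(=O)c2c[nH]c3ccccc23)cc1` differs from compound 2 by 1H-indol-3-yl in place of 1H-pyrrol-2-yl on a carbonyl carbon. For the measured compounds named here, no measured step covers this change; the one known step shows only that the group on the carbonyl carbon can move the number, and the limit on compound 2 leaves the starting point open. Compound 3 is therefore expected to remain in the weak region, the estimated step of an at least 1.2-fold lower number from compound 2 to compound 3 (0.09 log units; that floor lies within the scatter) carrying wide uncertainty. The estimate for compound 3 in this assay is 8000 nM, within 2000 nM to 30000 nM.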

Compound 3, half-maximal inhibitory concentration: > 10000 nM
Compound 3 ended at the assay's limit (the forecaster's own chance of this, stated with the estimate: 45%); at least 1.2-fold (0.09 log units) between middle value and limit.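

Enlarging the group on the carbonyl carbon to 1H-indol-3-yl, with its added six-membered aromatic ring of carbon only, does not bring the number back toward that of compound 1: in this assay the change from phenyl gives an at least 2.4-fold higher number from compound 1 to compound 3 (0.39 log units; beyond the scatter) and so joins the pyrrole change as a step toward weaker inhibition. Compound 2 and compound 3 both stand at limits, so the step between them cannot be read, and no order of the two ring groups follows. The series now gathers at the top of the measurable range: the limit of > 10000 nM in this assay, at which 2 of the 3 values shown sit.

Going by these compounds, how far compound 2 and compound 3 actually lie past that limit remains open. Also open, on these data alone, is whether a saturated alkyl chain or a phenyl bearing a carboxylic acid on the carbonyl carbon would stay near compound 1 or give a lower number.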